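A few compounds are considered here, and "the series" means these few. Any claim that something is new, unique, unknown or untested is made for them only; others in the source may bear on it.

Measured compounds:
compound 1, `Brc1ccc2[nH]c(-c3cn(-c4ccccc4)nc3-c3ccccc3)nc2c1`: 830 nM
compound 2, `FC(F)(F)c1ccc2[nH]c(-c3cn(-c4ccccc4)nc3-c3ccccc3)nc2c1`: 2660 nM
compound 3, `O=C(OCc1ccccc1)c1ccc2[nH]c(-c3cn(-c4ccccc4)nc3-c3ccccc3)nc2c1`: 12600 nM

The three measured compounds share one core and differ only in the group on its aromatic carbon. In a functional assay on MCF7 cells (Homo sapiens) for antiproliferative activity, read by MTT assay, with a stated time of 48 h (a higher number here means a weaker inhibitor, a lower number a stronger inhibitor), compound 3 gives the highest number of the three: a 4.7-fold higher number from compound 2 to compound 3 (0.68 log units; beyond the scatter), and a 15-fold higher number from compound 1 to compound 3 (1.18 log units; beyond the scatter). The step between the other two is smaller, a 3.2-fold higher number from compound 1 to compound 2 (0.51 log units; beyond the scatter).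

Compound 4, `O=C(OCc1ccccc1)c1ccc2[nH]c(-c3cn(-c4ccccc4)nc3-c3ccc(Cl)cc3)nc2c1`, keeps the benzyloxycarbonyl group of compound 3 and differs from it in one place: chloro in place of hydrogen on an aromatic carbon. For the measured compounds named here, none of the measured steps touches this position; all three vary the substituent on the core, while the change from compound 3 to compound 4 sits on one of the phenyl rings, which is the same in every measured compound. The data therefore give no direct guide for this assay. In the absence of any bearing step, the expectation for compound 4 is a number close to that of compound 3, with an estimated step of a 1.3-fold lower number from compound 3 to compound 4 (0.12 log units; within the scatter), which lies within the scatter. Compound 4 is expected to give 9500 nM in this assay, with a range from 3500 nM to 26000 nM.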

Compound 4, half-maximal inhibitory concentration: 13900 nM
Estimate against measurement, compound 4: 1.5-fold (0.17 log units) below; measured number inside the range.
By their numbers in this assay, from the lowest: compound 1; then compound 2; then compounds 3 and 4 (each within the scatter of the next).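

Phenyl to 4-chlorophenyl is the first change in the series away from the substituent on the shared core, and in this assay it gives a 1.1-fold higher number from compound 3 to compound 4 (0.04 log units; within the scatter). For the compounds shown here, all the earlier steps varied the core substituent and lay beyond the scatter, whereas chloro on this aromatic carbon, para to a large group, does not separate the two compounds while benzyloxycarbonyl stays on the core. No measurement at hand bears on why this is so.

Going by these compounds alone, whether chloro reads the same with bromo or trifluoromethyl on the core remains open, as the only pair for this change carries benzyloxycarbonyl. Also open, from the compounds shown here alone, is how this position responds to groups other than chloro, such as an amine, a carboxylic acid or a longer chain, and how the other phenyl ring responds to substitution.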